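Aryl ether replaced by nitrile on the acylguanidine series

The source may hold more compounds than are shown below. What is called first, only, known or untested is meant among the compounds shown, and "the series" means these compounds.

Among the compounds with values here, compound 3 `Cc1cc(Oc2cccc(Cl)c2)c(S(C)(=O)=O)cc1C(=O)N=C(N)N` gives 21 nM in a functional assay for inhibition of sodium/hydrogen exchanger (Oryctolagus cuniculus) (on this read-out higher numbers stand for weaker inhibition and lower numbers for stronger inhibition), and stands highest of the three numbers so far. Compound 1 `Cc1cc(Sc2ccccc2Cl)c(S(C)(=O)=O)cc1C(=O)N=C(N)N` gives 14 nM in this assay, and compound 2 `Cc1cc(Oc2ccccc2)c(S(C)(=O)=O)cc1C(=O)N=C(N)N` gives 10 nM. Of the measured steps, only a 2.1-fold higher number from compound 2 to compound 3 (0.32 log units; beyond the scatter) lies beyond the scatter, while a 1.4-fold lower number from compound 1 to compound 2 (0.15 log units; within the scatter) and a 1.5-fold higher number from compound 1 to compound 3 (0.18 log units; within the scatter) fall within it; all three exchange one aryl group for another and stay small.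

Compound 4 `Cc1cc(C#N)c(S(C)(=O)=O)cc1C(=O)N=C(N)N` differs from compound 3 by cyano in place of 3-chlorophenoxy on an aromatic carbon. No measured step removes the aryl ether altogether, so this change is outside what the series has shown. A modest step towards a higher number is expected, a 2.1-fold higher number from compound 3 to compound 4 (0.33 log units; beyond the scatter), with wide uncertainty. For compound 4 the estimated value in this assay is 45 nM, within a range of 10 nM to 200 nM.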

Compound 4, half-maximal inhibitory concentration: 70 nM
The estimate for compound 4 lay 1.6-fold (0.19 log units) below the measured number; the range from low to high includes it.
By their numbers in this assay, from the lowest: compounds 2, 1 and 3 (each within the scatter of the next, the first and the last beyond it); then compound 4.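

Cyano in place of the aryl groups at this position gives a 3.3-fold higher number from compound 3 to compound 4 (0.52 log units; beyond the scatter) and a 7.0-fold higher number from compound 2 to compound 4 (0.85 log units; beyond the scatter) and a 5.0-fold higher number from compound 1 to compound 4 (0.70 log units; beyond the scatter) and each of these exceeds a 2.1-fold higher number from compound 2 to compound 3 (0.32 log units; beyond the scatter) seen among the aryl compounds. The core with cyano on this carbon still gives a measurable number in the assay, so an aryl ether or aryl thioether here is not required for inhibition, although all three aryl compounds give lower numbers. No evidence at hand accounts for the rise.

From the compounds shown here alone, whether an amine, a methoxy group or a longer alkyl chain on this carbon would track cyano or the aryl groups remains open.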